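The source may report more compounds than this note shows. Statements on the series, on what has been measured and on what is new or still open speak of the compounds shown alone.

Three compounds here share one core. In an ADME assay on cells (Homo sapiens) for cytotoxicity, read by polymerase chain reaction, with a stated time of 3 days (on this read-out lower numbers stand for higher toxicity in this test and higher numbers for lower toxicity in this test), compound 1 `Nc1nc(Cl)c(-c2nc3ccccc3o2)c(N[C@@H]2C[C@H](CO)[C@@H](O)[C@H]2O)n1` gives 12000 nM. Compound 2 `Nc1ncc(-c2nc3ccccc3s2)c(N[C@@H]2C[C@H](CO)[C@@H](O)[C@H]2O)n1` reaches only a limit of this assay, > 25000 nM. Among the compounds with values here, compound 3 `Cc1nc(N)nc(N[C@@H]2C[C@H](CO)[C@@H](O)[C@H]2O)c1-c1nc2ccccc2s1` gives 4000 nM, the lowest of the two numbers known, standing beyond the scatter from compound 1. Within the data shown here, the only single-change step measured is an at least 6.2-fold lower number from compound 2 to compound 3 (0.79 log units; beyond the scatter). Compound 4 `Cc1nc(NCCNC(=O)NC(C)(C)C)nc(N[C@@H]2C[C@H](CO)[C@@H](O)[C@H]2O)c1-c1nc2ccccc2s1` differs from compound 3 by 2-(((tert-butyl)carbamoyl)amino)ethyl in place of hydrogen on a nitrogen on an aromatic ring. Among the measured compounds shown here, no measured step touches a change on that nitrogen, so the methyl step offers no guide, and no shift beyond the scatter is expected in this assay. Compound 4 is expected to give about 6000 nM, between 2000 nM and 25000 nM, an estimated step of a 1.5-fold higher number from compound 3 to compound 4 (0.18 log units; within the scatter).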

Compound 4, half-maximal cytotoxic concentration: > 25000 nM
Compound 4: a limit, no number; the forecaster's own chance of this, stated with the estimate: 20%; at least 4.1-fold (0.61 log units) between middle value and limit.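

Within the data shown here, on a nitrogen on an aromatic ring, where no earlier step reached, 2-(((tert-butyl)carbamoyl)amino)ethyl in place of hydrogen gives an at least 6.2-fold higher number from compound 3 to compound 4 (0.79 log units; beyond the scatter) in this assay. This shows that a change at this position can move the read-out beyond the scatter, towards lower toxicity in this test. Compound 4 stands at a limit and not at a number, so the full size of the step stays unknown: the limit of > 25000 nM in this assay, at which 2 of the 4 values shown sit.

The compounds shown leave open whether methyl or a plain ethyl chain on this nitrogen would shift the read-out as far. They also leave open whether a chain ending in an amine or a carboxylic acid would do so.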